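A few compounds are considered here, and "the series" means these few. Any claim that something is new, unique, unknown or untested is made for them only; others in the source may bear on it.

Compound 1 `C=Cc1ccc(S(=O)(=O)Nc2ccc3oc(-c4ccccc4)nc3c2)cc1` sits at a limit of an assay on cells for inhibition of HSP60/HSP10 (Homo sapiens), with a stated time of 60 min; on this read-out lower numbers stand for stronger inhibition and higher numbers for weaker inhibition: compound 1 gives > 100000 nM. Compound 2 `COc1ccc(Cl)cc1S(=O)(=O)Nc1ccc2oc(-c3ccccc3)nc2c1` also sits at a limit: in this assay compound 2 gives > 100000 nM. The step that the two limits leave unreadable from compound 1 to compound 2 is therefore unreadable, and the limit of > 100000 nM in this assay, at which 2 of the 2 values shown sit, holds both values. Compound 3 `O=S(=O)(Nc1ccc2oc(-c3ccccc3)nc2c1)c1ccc(O)cc1` carries 4-hydroxyphenyl in place of 5-chloro-2-methoxyphenyl on a sulfonyl sulfur. Going by the values given here, no measured step bears on this change, and no direction can be read from compound 1 or compound 2. Compound 3 is therefore expected to stay near the limit, with the step of a number no higher from compound 2 to compound 3 (the limit leaves the size open) taken as flat. The estimate for compound 3 is 100000 nM, ranging from 20000 nM to 300000 nM.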

Compound 3, half-maximal inhibitory concentration: 88000 nM
The estimate for compound 3 lay 1.1-fold (0.06 log units) above the measured number; low and high end bracket the measured number.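

Compound 3 gives a number rather than a limit in this assay, so a change on the sulfonyl sulfur can bring this series into the readable range, while the other two values are limits: the limit of > 100000 nM in this assay, at which 2 of the 3 values shown sit.

Against those limits only floors can be stated: an at least 1.1-fold lower number from compound 2 to compound 3 (0.05 log units; that floor lies within the scatter), and for hydroxy in place of vinyl on an aromatic carbon, an at least 1.1-fold lower number from compound 1 to compound 3 (0.05 log units; that floor lies within the scatter). Both floors lie within the scatter, so no order among the three compounds can be claimed.

As far as these compounds go, the true size of either step remains open. Also open, from the compounds shown here alone, is how an amine or a carboxylic acid in place of the hydroxy group would read.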